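The compounds below may be only part of what the source reports. "The series", "measured", "known", "first", "only" and "open" are said of these compounds alone.

Compound 1 `CC1(COc2ccc(-c3ccc(F)cc3)cc2)CCn2cc([N+](=O)[O-])nc2O1` was tested in an ADME assay on MRC5 cells (Homo sapiens) for cytotoxicity, read by resazurin assay, with a stated time of 72 h; on this read-out lower numbers stand for stronger inhibition and higher numbers for weaker inhibition. In this assay compound 1 reaches only the limit of > 64000 nM. Compound 3 `CC1(COc2ccc(-c3ccc(F)nc3)cc2)CCn2cc([N+](=O)[O-])nc2O1` differs from it by a single exchange: 6-fluoropyridin-3-yl in place of 4-fluorophenyl on an aromatic carbon. In this assay compound 3 likewise reaches only the limit of > 64000 nM. The step from compound 1 to compound 3 is therefore a step that the two limits leave unreadable from compound 1 to compound 3, and the limit of > 64000 nM in this assay, at which 2 of the 3 values shown sit, marks where both sit. Compound 2 `O=[N+]([O-])c1cn2c(n1)OC(COc1cccc(-c3ccc(F)cc3)n1)CC2` has a different core; the difference between the two cores is not broken down here. In this assay, among the measured compounds shown here, compound 2 gives 59000 nM, the only number among the three. Compound 4 `O=[N+]([O-])c1cn2c(n1)OC(COc1cccc(-c3ccc(F)nc3)n1)CC2` is not yet measured, and it differs from compound 2 as follows: 6-fluoropyridin-3-yl in place of 4-fluorophenyl on an aromatic carbon. The place is not the same: in compound 1 the exchange sits on a six-membered aromatic ring of carbon only, para to a large group, while in compound 2 it sits on a six-membered aromatic ring with 1 nitrogen, next to the ring nitrogen, meta to a large group, so it is the same kind of change, not the same. Because a step that the two limits leave unreadable from compound 1 to compound 3 was unreadable, the expected step is a 1.0-fold higher number from compound 2 to compound 4 (0.01 log units; within the scatter). This expectation rests on compound 2 standing at 59000 nM and on (the limit of > 64000 nM in this assay, at which 2 of the 3 values shown sit). Compound 4 is expected at 60000 nM, between 30000 nM and 120000 nM.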

Compound 4, half-maximal inhibitory concentration: 35000 nM
Compound 4: middle estimate off by 1.7-fold (0.23 log units), on the high side; the range from low to high includes it.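

In this assay, 6-fluoropyridin-3-yl in place of 4-fluorophenyl on the core of compound 2 gives a 1.7-fold lower number from compound 2 to compound 4 (0.23 log units; within the scatter), so on this core the exchange leaves the read-out within the usual scatter of repeated measurements. Among the compounds shown here, the same kind of exchange on the core of compound 1 cannot be read, because both of its values are limits and not numbers: the limit of > 64000 nM in this assay, at which 2 of the 4 values shown sit. The compounds therefore show no step beyond the scatter in the one readable pair, but they do not show that the change carries over from one core to the other with the same size, as only one of the two steps has a size and the exchange sits in a different place in each core.

All four compounds keep a fluorine on the outer ring, so the compounds shown leave open how an amine or a carboxylic acid in that place would read in this assay. Also open, going by these compounds, is what a longer chain between the core and the inner ring would do.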